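Hexylsulfanyl in place of ethoxy on the shared core

A few compounds are considered here, and "the series" means these few. Any claim that something is new, unique, unknown or untested is made for them only; others in the source may bear on it.

Compound 1 `CCOc1nc(N)nc2c1ncn2/C=C1/CC1(CO)CO` serves as the reference point of the series. In an ADME assay on Akata cells (Homo sapiens) for cytotoxicity, with a stated time of 7 days (on this read-out higher numbers stand for lower toxicity in this test and lower numbers for higher toxicity in this test), compound 1 gives only a limit of the assay, > 20000 nM. Compound 2 `CN(C)c1nc(N)nc2c1ncn2/C=C1/CC1(CO)CO` likewise gives only a limit in this assay, > 24000 nM. Compound 3 `CCCNc1nc(N)nc2c1ncn2/C=C1/CC1(CO)CO` also gives only a limit in this assay, > 24000 nM. Since all three values are limits, compound 1 cannot be placed against the other two: the limit of > 20000 nM in this assay, at which 1 of the 3 values shown sits, and the limit of > 24000 nM in this assay, at which 2 of the 3 values shown sit, tell where the three values sit. The steps a step that the two limits leave unreadable from compound 1 to compound 2, a step that the two limits leave unreadable from compound 1 to compound 3 and a step that the two limits leave unreadable from compound 2 to compound 3 are therefore all unreadable in size. Compound 4 `CCCCCCSc1nc(N)nc2c1ncn2/C=C1/CC1(CO)CO` differs from compound 1 by hexylsulfanyl in place of ethoxy on an aromatic carbon. Among the measured compounds shown here, none of the measured steps can be read, so neither a direction nor a size can be drawn from them for this change. For compound 4 the expectation is a step of a number no higher from compound 1 to compound 4 (the limit leaves the size open) of no readable size. Compound 4 is expected to give 20000 nM, within the range 5000 nM to 50000 nM, and most likely once more only a limit of this assay.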

Compound 4, half-maximal cytotoxic concentration: > 20000 nM
Compound 4 gave a limit, no number; the forecaster's own chance of this, stated with the estimate: 65%; the middle value sits exactly at the limit.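

In this assay compound 4 gives only a limit, > 20000 nM. Among the compounds shown here, no step from compound 1, compound 2 or compound 3 to compound 4 can therefore be read. The compounds shown leave open whether any of these replacements on the shared core changes the read-out, and by how much.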